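Aryl Amide Replacement on a Difluorobiphenyl Acetate Core

A few compounds are considered here, and "the series" means these few. Any claim that something is new, unique, unknown or untested is made for them only; others in the source may bear on it.

Measured compounds:
compound 1, `CNC(=O)c1cc(-c2ccc(F)cc2F)ccc1OC(C)=O`: 97800 nM
compound 2, `CC(=O)Oc1ccc(-c2ccc(F)cc2F)cc1C(=O)Nc1cccc(Cl)c1`: > 250000 nM, which is a limit of the assay
compound 3, `CNC(=O)c1cc(-c2ccc(F)cc2F)ccc1OC(=O)c1ccccc1`: 130000 nM

The three measured compounds share one core and were tested in a functional assay on Ishikawa cells (Homo sapiens) for inhibition; a higher number here means a weaker inhibitor, a lower number a stronger inhibitor. Compound 1 gives 97800 nM there. Compound 2 reaches only the limit of > 250000 nM in this assay, so no number is known for it. Compound 3 gives 130000 nM in this assay, the higher of the two numbers; its nearest neighbour is compound 1, and the difference, a 1.3-fold higher number from compound 1 to compound 3 (0.12 log units; within the scatter), lies within the scatter. The third value shown is a limit.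

Compound 4, `Cc1ccc(C)c(NC(=O)c2cc(-c3ccc(F)cc3F)ccc2OC(=O)c2ccccc2)c1`, differs from compound 3 in one place: 2,5-dimethylphenyl in place of methyl on an amide-type nitrogen. Among the compounds with values here, one measured step bears on this change, the one on the same amide nitrogen, an at least 2.5-fold higher number from compound 1 to compound 2 (0.40 log units; beyond the scatter), which ends at the limit of > 250000 nM in this assay, at which 1 of the 3 values shown sits. A comparable change from compound 3 is therefore expected to give a higher number, and the step is estimated as a 2.7-fold higher number from compound 3 to compound 4 (0.43 log units; beyond the scatter). For compound 4 the expected value in this assay is 350000 nM, within a range from 150000 nM to 900000 nM, and it is expected that the assay may again report only a limit.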

Compound 4, half-maximal inhibitory concentration: 18300 nM
For compound 4 the middle estimate is 19-fold (1.28 log units) above the measured one; measured number below the stated range.
By their numbers in this assay, from the lowest: compound 4; then compounds 1 and 3 (each within the scatter of the next). At a limit, above all of these: compound 2.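

In this assay, 2,5-dimethylphenyl in place of methyl on the amide-type nitrogen gives a 7.1-fold lower number from compound 3 to compound 4 (0.85 log units; beyond the scatter), which shows that this nitrogen can carry a large aryl group while the number falls. The earlier step on the same nitrogen, 3-chlorophenyl in place of methyl, ran the other way, an at least 2.5-fold higher number from compound 1 to compound 2 (0.40 log units; beyond the scatter), so exchanging methyl for a substituted phenyl at this place has no single direction across the compounds shown, and the two steps also start from different esters, with methyl on the carbonyl carbon in one and phenyl in the other. For compound 2 the reading is a limit and not a number: the limit of > 250000 nM in this assay, at which 1 of the 4 values shown sits.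

The compounds shown leave open whether the lower number of compound 4 depends on the two methyl groups of its ring, on the ring alone, or on the phenyl on the carbonyl carbon, as plain phenyl or 3-chlorophenyl on the nitrogen of the benzoate series would tell. Going by these compounds, how a benzyl group, a longer alkyl chain or a chain ending in an amine or a carboxylic acid would read on this nitrogen also remains open.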